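Phenyl for pyrimidinyl in the spirocyclic amide series

The compounds below may be only part of what the source reports. "The series", "measured", "known", "first", "only" and "open" are said of these compounds alone.

Compound 1 `Cc1ccc(-c2ncccn2)c(C(=O)N2CC3(CC3)C[C@H]2CNc2ccc(C(F)(F)F)cn2)n1` stands highest of the three numbers in a functional assay on HEK293 cells for antagonist activity at Orexin receptor type 2 (Homo sapiens), read by FLIPR and calcium flux (on this read-out lower numbers stand for lower potency and higher numbers for higher potency (the scale is a negative logarithm)), where compound 1 gives 7.5. Compound 2 `O=C(c1nc(C(F)(F)F)ccc1-c1ncccn1)N1CC2(CC2)C[C@H]1CNc1ccc(C(F)(F)F)cn1` gives 5 and compound 3 `O=C(c1ncccc1-c1ncccn1)N1CC2(CC2)C[C@H]1CNc1ccc(C(F)(F)F)cn1` gives 5. Both changes at the methyl carbon cost heavily: a number 2.50 log units lower from compound 1 to compound 2 (beyond the scatter) and a number 2.50 log units lower from compound 1 to compound 3 (beyond the scatter), while no change at the digits printed from compound 2 to compound 3 (within the scatter).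

Compound 4 `Cc1ccc(-c2ccccc2)c(C(=O)N2CC3(CC3)C[C@H]2CNc2ccc(C(F)(F)F)cn2)n1` carries a different change, (phenyl in place of pyrimidin-2-yl on an aromatic carbon). Among the measured compounds shown here, none of the measured steps touches this aryl group, so nothing here bears directly on it; the large losses from compound 1 to compounds 2 and 3 show only that this core reacts strongly to small changes on the pyridine ring, which argues for caution. With the methyl retained, a moderate loss in this assay is expected rather than a collapse of the kind seen in compound 2 or compound 3. For compound 4 the estimate is 7, between 6 and 7.8, meaning an expected step of a number 0.50 log units lower from compound 1 to compound 4 (beyond the scatter).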

Compound 4, negative logarithm of the antagonist equilibrium constant: 8
Beside the measured number, compound 4's estimate is 1.00 log units below it, and the stated range ends below it.
By their numbers in this assay, from the lowest: compounds 2 and 3 (each within the scatter of the next); then compound 1; then compound 4.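

In this assay, phenyl in place of pyrimidin-2-yl gives a number 0.50 log units higher from compound 1 to compound 4 (beyond the scatter), so this aromatic carbon, ortho to a large group, accepts a ring of carbon only, with a modest gain rather than a loss. In this pair, the 2 hydrogen-bond acceptors counted on pyrimidin-2-yl are not needed to hold the number, and the core is therefore not sensitive to every change on the pyridine ring, unlike the changes at the methyl carbon. No measurement shown accounts for the gain.

As far as these compounds go, whether pyridin-2-yl, with a single ring nitrogen, would track phenyl or pyrimidin-2-yl remains open, as does the effect of a fluorine or methoxy group on the phenyl ring. Also open, from the compounds shown here alone, is whether phenyl would give a similar step with the trifluoromethyl of compound 2 or the hydrogen of compound 3 in place of the methyl.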